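Swapping Methoxy for Methyl: An Expected Small Rise

This account rests on a few compounds, and the source may have more. Where it says the series, first, only, none or still open, it means among the compounds named here.

compound 1 `Cc1ccccc1N1C(=O)/C(=C/c2ccc(O)c(Cl)c2)S/C1=N\CCCF`: 3.4
compound 2 `CCC/N=C1\S/C(=C\c2ccc(O)c(Cl)c2)C(=O)N1c1ccccc1OC`: 3.3

The two compounds were read in a physicochemical assay for lipophilicity, read by HPLC, at pH 7.4; on this read-out higher numbers stand for higher lipophilicity and lower numbers for lower lipophilicity. Going by the values given here, compound 2 stands at 3.3 and compound 1 at 3.4, and these two values lie within the usual scatter of each other, so they set no order between the compounds.

Compound 3 `CCC/N=C1\S/C(=C\c2ccc(O)c(Cl)c2)C(=O)N1c1ccccc1C` has not yet been measured. It departs from compound 2 in one place, with methyl in place of methoxy on an aromatic carbon, ortho to a large group (methyl in place of methoxy on an aromatic carbon). The same difference reads 2-methoxyphenyl to 2-methylphenyl. Among the compounds with values here, no measured pair shows this change, so its size rests on judgement alone. The 2-methylphenyl group of compound 3 also occurs in compound 1 at 3.4, but that compound carries a different chain as well. A modest rise is expected, close to the edge of the scatter, as an estimated step (a number 0.30 log units higher from compound 2 to compound 3 (within the scatter)). For compound 3 the estimated value is 3.6, with an expected range from 3.3 to 4.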

Compound 3, distribution coefficient: 3.8
Compound 3: the middle estimate sits 0.20 log units below what was measured; low and high end bracket the measured number.
By their numbers in this assay, from the lowest: compounds 2 and 1 (each within the scatter of the next); then compound 3.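

In this assay, going by these compounds alone, methyl in place of methoxy on an aromatic carbon, ortho to a large group, gives a number 0.50 log units higher from compound 2 to compound 3 (beyond the scatter) and so provides the first measured reading of this change, one that lies beyond the scatter. A second single-place comparison now also exists on the saturated chain, where hydrogen in place of fluoro gives a number 0.40 log units higher from compound 1 to compound 3 (beyond the scatter) as a step that likewise lies beyond the scatter. Thus compound 3 stands clear of both earlier compounds, which themselves could not be ordered, though no measured evidence here accounts for either step.

The compounds shown leave open whether the step from methoxy to methyl reflects something particular to these two groups or extends to others at this position, such as ethyl, chloro or hydroxyl, and whether it would keep its size with the fluorinated chain of compound 1 in place. They also leave open how the read-out would respond on the chain to a longer chain or to an amine.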